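A Longer Amine Chain on a Shared Core

The source may report more compounds than this note shows. Statements on the series, on what has been measured and on what is new or still open speak of the compounds shown alone.

Two compounds have been measured in a functional assay on HT-29 cells (Homo sapiens) for cytotoxicity, read by neutral red uptake, with a stated time of 72 h; a higher number here means a weaker inhibitor, a lower number a stronger inhibitor:

Compound 1, `CCCCNc1nc(SCC)nc2ncccc12`: 25300 nM
Compound 2, `CCCCNc1nc(SC(C)C)nc2ncccc12`: 32100 nM

Of these two numbers, that of compound 2 stands higher on paper, but the step of a 1.3-fold higher number from compound 1 to compound 2 (0.10 log units; within the scatter) lies within the scatter, so the two compounds are not told apart by this assay.

Compound 3, `CCCCCCNc1nc(SC(C)C)nc2ncccc12`, differs from compound 2 by ethyl in place of hydrogen on a saturated chain carbon, four bonds along the chain from a nitrogen on an aromatic ring. Going by the values given here, the only measured step concerns the chain on the sulfur, not the chain on the amine nitrogen, and that step was itself within the scatter. Among the compounds with values here, no measured step touches the place that changes here, so nothing points up or down. No step beyond the scatter is therefore expected, and the guess carries a wide band. Compound 3 is expected to give about 32000 nM, within the range 11000 nM to 95000 nM. This estimate amounts to a 1.0-fold lower number from compound 2 to compound 3 (0.00 log units; within the scatter).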

Compound 3, half-maximal inhibitory concentration: 20200 nM
Estimate against measurement, compound 3: 1.6-fold (0.20 log units) above; the measured number falls inside the stated range.
By their numbers in this assay, from the lowest: compounds 3, 1 and 2 (each within the scatter of the next).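

Going by these compounds alone, compound 3 brings the first measured change on the amine chain, and in this assay ethyl in place of hydrogen at this place gives a 1.6-fold lower number from compound 2 to compound 3 (0.20 log units; within the scatter). The assay therefore does not tell compound 2 and compound 3 apart, so this added ethyl has no effect that can be separated from ordinary repeat-to-repeat variation. Like the earlier step on the sulfur chain, this one gives no sign of a direction, but it now extends that reading to a second place on the shared core, and no other data shown bear on this result.

From the compounds shown here alone, whether a still longer chain on the amine nitrogen would move the number beyond the scatter remains open. So does the outcome of placing a carboxylic acid or a second amine on that chain.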